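Piperidin-1-yl in place of pyrrolidin-1-yl

The source may hold more compounds than are shown below. What is called first, only, known or untested is meant among the compounds shown, and "the series" means these compounds.

Going by the values given here, in a functional assay on A549 cells (Homo sapiens) for antiproliferative activity, with a stated time of 72 h (a higher number here means a weaker inhibitor, a lower number a stronger inhibitor), compound 2 (`COc1cc(OC)c(C(=O)/C=C/c2ccccc2Cl)c(O)c1CN1CCCC1`) gives 2600 nM as the lower of the two numbers so far, with compound 1 (`COC(=O)CN(C)Cc1c(OC)cc(OC)c(C(=O)/C=C/c2ccccc2Cl)c1O`) at 9100 nM as the higher. The change to compound 3 (`COc1cc(OC)c(C(=O)/C=C/c2ccccc2Cl)c(O)c1CN1CCCCC1`) is piperidin-1-yl in place of pyrrolidin-1-yl on a saturated chain carbon bound to an aromatic carbon and it sits on a saturated chain carbon bound to an aromatic carbon. Among the compounds with values here, the only measured step at this place is a 3.5-fold lower number from compound 1 to compound 2 (0.54 log units; beyond the scatter) and it was modest, but it replaced ((methoxycarbonyl)methyl)(methyl)amino rather than one ring with another. In this assay a smaller change is therefore expected, probably none beyond the scatter, and the expected step is a 1.0-fold lower number from compound 2 to compound 3 (0.02 log units; within the scatter) here. Compound 3 is estimated at 2500 nM within a range from 1100 nM to 6000 nM overall.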

Compound 3, half-maximal inhibitory concentration: 2800 nM
Estimate against measurement, compound 3: 1.1-fold (0.05 log units) below; the range from low to high includes it.
By their numbers in this assay, from the lowest: compounds 2 and 3 (each within the scatter of the next); then compound 1.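

In this assay the change from a five-membered to a six-membered ring on a saturated chain carbon bound to an aromatic carbon gives a 1.1-fold higher number from compound 2 to compound 3 (0.03 log units; within the scatter) and so leaves the two rings indistinguishable here. The step of a 3.3-fold lower number from compound 1 to compound 3 (0.51 log units; beyond the scatter) shows that piperidin-1-yl, like pyrrolidin-1-yl, gives a lower number than ((methoxycarbonyl)methyl)(methyl)amino. No available evidence explains these results.

Still open, as far as these compounds go, is whether a ring holding oxygen, such as morpholin-4-yl, or a second nitrogen, such as piperazin-1-yl, would fit the same pattern. Also open, from the compounds shown here alone, is how a simple dimethylamino group would compare.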